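The compounds below may be only part of what the source reports. "The series", "measured", "known", "first", "only" and "open" are said of these compounds alone.

Among the compounds with values here, in an ADME assay on MT4 cells (Homo sapiens) for cytotoxicity, read by MTT assay, with a stated time of 5 days (on this read-out lower numbers stand for higher toxicity in this test and higher numbers for lower toxicity in this test), compound 1 (`C=CCNc1cc(Oc2c(C)cc(/C=C/C#N)cc2C)nc(Nc2ccc(C#N)cc2)n1`) gives 3050 nM, the lowest of the three numbers measured so far. Compound 3 (`Cc1cc(/C=C/C#N)cc(C)c1Oc1cc(NCCN2CCN(C)CC2)nc(Nc2ccc(C#N)cc2)c1`) gives 7960 nM, the nearest value but still beyond the scatter, and compound 2 (`C=CCNc1cc(Oc2c(C)cc(/C=C/C#N)cc2C)cc(Nc2ccc(C#N)cc2)n1`) gives 82100 nM, the furthest. Compound 4 (`Cc1cc(/C=C/C#N)cc(C)c1Oc1cc(NCC2CCCO2)nc(Nc2ccc(C#N)cc2)n1`) departs from compound 1 at a single place: oxolan-2-yl in place of vinyl on a saturated chain carbon bound to a nitrogen on an aromatic ring. In words, oxolan-2-yl stands in place of vinyl on a saturated chain carbon bound to a nitrogen on an aromatic ring.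

Within the data shown here, only one measured step bears on this change: a 10-fold lower number from compound 2 to compound 3 (1.01 log units; beyond the scatter). It replaces vinyl at the same kind of place, but with (4-methylpiperazin-1-yl)methyl. That step is large and runs downward, yet it starts from a different core and brings in a different group, so it is a weak guide here. Compound 3 still ends at 7960 nM, and compound 1 already sits lower at 3050 nM. No step beyond the scatter is therefore expected in this assay, with a slight lean upward if anything. The expected size is a 1.3-fold higher number from compound 1 to compound 4 (0.12 log units; within the scatter). For compound 4 the estimated value is 4000 nM, with an expected range from 1300 nM to 15000 nM.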

Compound 4, half-maximal cytotoxic concentration: > 268000 nM
Compound 4 ended at the assay's limit; the forecaster's own chance of this, stated with the estimate: 8%; middle value at least 67-fold (1.82 log units) away from the limit.
By their numbers in this assay, from the lowest: compound 1; then compound 3; then compound 2. At a limit, above all of these: compound 4.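

Oxolan-2-yl in place of vinyl on a saturated chain carbon bound to a nitrogen on an aromatic ring gives an at least 87-fold higher number from compound 1 to compound 4 (1.94 log units; beyond the scatter) in this assay, so a single change at this place on the core of compound 1 can move the read-out strongly upward, whereas the only earlier step at this kind of place, a 10-fold lower number from compound 2 to compound 3 (1.01 log units; beyond the scatter), ran downward. That earlier step has a different core and a different incoming group, so the two opposite directions show how much can turn on this place but set no rule for it. The value of compound 4 is a limit of the assay and not a number, so the step has a lower bound and no exact size, and compound 4 is the only compound shown to reach this limit: the limit of > 268000 nM in this assay, at which 1 of the 4 values shown sits.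

The compounds shown do not separate the ring of oxolan-2-yl from its oxygen, a question that a cyclopentyl group or a 2-methoxyethyl chain at the same place would address. On these data alone, it also remains open how (4-methylpiperazin-1-yl)methyl would read on the core of compound 1.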